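The source may report more compounds than this note shows. Statements on the series, on what has been measured and on what is new or still open speak of the compounds shown alone.

Going by the values given here, compound 1 `c1ccc(N2N=NCC2c2ccncc2)cc1` is the starting point of the pair in hand; in a functional assay on the whole organism with Mus musculus as the target, in the maximal electroshock model (on this read-out higher numbers stand for an effect only at larger amounts of compound and lower numbers for an effect already at smaller amounts), compound 1 gives 165 mg/kg, the lowest of the two numbers so far. Among the compounds with values here, compound 2 `FC(F)(F)c1ccc(N2N=NCC2c2ccncc2)cc1` gives 689 mg/kg in this assay, and the one measured step, a 4.2-fold higher number from compound 1 to compound 2 (0.62 log units; beyond the scatter), is the only guide for the next change. Compound 3 `FC(F)(F)c1cccc(N2N=NCC2c2ccncc2)c1` differs from compound 1 by trifluoromethyl in place of hydrogen on an aromatic carbon. The same group added at a different position is expected to move this assay in the same direction, so for compound 3 the estimated step is a 2.4-fold higher number from compound 1 to compound 3 (0.38 log units; beyond the scatter). Compound 3 is therefore expected to give about 400 mg/kg, between 200 mg/kg and 900 mg/kg.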

Compound 3, dose for half-maximal effect: 52.1 mg/kg
For compound 3 the middle estimate is 7.7-fold (0.89 log units) above the measured one; measured number outside the range, below it.
By their numbers in this assay, from the lowest: compound 3; then compound 1; then compound 2.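

In this assay trifluoromethyl in place of hydrogen, meta to a large group, gives a 3.2-fold lower number from compound 1 to compound 3 (0.50 log units; beyond the scatter). The same group at another position on that ring gives a 4.2-fold higher number from compound 1 to compound 2 (0.62 log units; beyond the scatter), so within these compounds the direction of the step depends on where the trifluoromethyl sits. Nothing available explains this difference between the two positions. Open, from the compounds shown here alone, is whether chlorine, methoxy or an amine at the position of compound 3 moves the number in the same direction, or whether this holds only for trifluoromethyl.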